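Acetamido in place of methyl: cytotoxicity outlook for compound 3

This account rests on a few compounds, and the source may have more. Where it says the series, first, only, none or still open, it means among the compounds named here.

Two members of the series have numbers in an ADME assay on L02 cells (Homo sapiens) for cytotoxicity, read by MTT assay, with a stated time of 24 h; a lower number here means a stronger inhibitor, a higher number a weaker inhibitor. Compound 1 `N#Cc1ccc(S(=O)(=O)N2C/C(=C\c3cccc(F)c3)C(=O)/C(=C/c3cccc(F)c3)C2)cc1` gives 15500 nM. Compound 2 `Cc1ccc(S(=O)(=O)N2C/C(=C\c3ccc(F)cc3)C(=O)/C(=C/c3ccc(F)cc3)C2)cc1` gives 14000 nM. The two numbers sit within the usual scatter of each other, so nothing separates compound 2 from compound 1 in this assay; both are weak inhibitors of the cells. Compound 3 `CC(=O)Nc1ccc(S(=O)(=O)N2C/C(=C\c3ccc(F)cc3)C(=O)/C(=C/c3ccc(F)cc3)C2)cc1` has not yet been measured in this assay. It differs from compound 2 in one place: acetamido in place of methyl on an aromatic carbon. No measured pair in the series makes a change of this kind, so there is no shown step to lean on. Among the compounds with values here, with the only two numbers in hand lying so close together, the expected step is a 1.1-fold higher number from compound 2 to compound 3 (0.03 log units; within the scatter), none beyond the scatter in either direction. Compound 3 is therefore expected to give about 15000 nM in this assay, with an estimated range from 7000 nM to 35000 nM.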

Compound 3, half-maximal inhibitory concentration: 19400 nM
Estimate against measurement, compound 3: 1.3-fold (0.11 log units) below; the range from low to high includes it.
By their numbers in this assay, from the lowest: compounds 2, 1 and 3 (each within the scatter of the next).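

In this assay, within the data shown here, acetamido in place of methyl on an aromatic carbon, para to a large group, gives a 1.4-fold higher number from compound 2 to compound 3 (0.14 log units; within the scatter) and is the first single-place step. The position therefore accepts the change from methyl, with 1 heavy atom, to acetamido, with 4 heavy atoms, 1 hydrogen-bond donor and 1 hydrogen-bond acceptor, without a step beyond the scatter. No measurement bearing on this result is at hand.

On these data alone, whether an amine or a carboxylic acid on the same aromatic carbon would also stay within the scatter of compound 2 remains open. Also open is whether acetamido in place of methyl would give a similar step with the fluorines placed as in compound 1, since the only step shown has them as in compound 2.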